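The compounds below may be only part of what the source reports. "The series", "measured", "known", "first", "only" and "open" are said of these compounds alone.

The measured compounds:
Compound 1, `CC1=C(N2CC2)C(=O)C(Cc2ccccc2)=C(N2CC2)C1=O`: in a functional assay on L1210 cells (Mus musculus), with a stated time of 1 days (on this read-out lower numbers stand for lower potency and higher numbers for higher potency (the scale is a negative logarithm)), compound 1 gives 4.74.
Compound 2, `CC1=C(N2CC2)C(=O)C(CCCOC(N)=O)=C(N2CC2)C1=O`: in this assay compound 2 gives 5.55.
Compound 3, `CC1=C(N2CC2)C(=O)C(CCCc2ccccc2)=C(N2CC2)C1=O`: in this assay compound 3 gives 3.93.

Compound 2 stands highest of the three in this assay. Its nearest neighbour is compound 1, with a number 0.81 log units higher from compound 1 to compound 2 (beyond the scatter), and the furthest is compound 3, with a number 1.62 log units lower from compound 2 to compound 3 (beyond the scatter). Between compound 1 and compound 3 the shift is a number 0.81 log units lower from compound 1 to compound 3 (beyond the scatter).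

Compound 4, `CC1=C(N2CC2)C(=O)C(C(C)COC(N)=O)=C(N2CC2)C1=O`, has not yet been measured. It differs from compound 2 in that (a group of 7 heavy atoms (4 carbon, 1 nitrogen, 2 oxygen; no ring) in place of a group of 7 heavy atoms (4 carbon, 1 nitrogen, 2 oxygen; no ring), on a double-bonded ring carbon); the two have the same atoms, joined differently. For the measured compounds named here, no measured step repeats this change. The two steps that involve compound 2 both exchange the carbamate-bearing chain for an aromatic group, and they show that keeping the carbamoyloxy chain sits at the high end of the three numbers. Compound 4 keeps every atom of that chain, so the expectation is for a small movement at most, likely within or close to the scatter, with no firm direction. For compound 4 in this assay the estimate is 5.35, from 4.75 to 5.95. That estimate means an expected step of a number 0.20 log units lower from compound 2 to compound 4 (within the scatter).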

Compound 4, logarithm of the reciprocal of the active concentration, log(1/C): 5.93
The estimate for compound 4 lay 0.58 log units below the measured number; low and high end bracket the measured number.
By their numbers in this assay, from the lowest: compound 3; then compound 1; then compound 2; then compound 4.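

In this assay, the same atoms joined differently on the double-bonded ring carbon do not give the same number: a number 0.38 log units higher from compound 2 to compound 4 (beyond the scatter), so this position responds to how the chain is connected and not only to which atoms it holds. The rearranged chain also stands further from the aromatic group of compound 1, with a number 1.19 log units higher from compound 1 to compound 4 (beyond the scatter), compared with a number 0.81 log units higher from compound 1 to compound 2 (beyond the scatter) for the unbranched carbamate chain. Nothing available here bears on the reason for this shift.

The compounds shown leave open how much of the result depends on the carbamoyloxy group itself, since it remains unknown what a hydroxyl or an amine would give in its place on the branched chain. They also leave open whether a longer branched chain, or an ethyl group at the branch in place of the methyl, would follow the step seen here or reverse it.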